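Swapping a Thiophene for a Furan on a Pyridine Core

The source may hold more compounds than are shown below. What is called first, only, known or untested is meant among the compounds shown, and "the series" means these compounds.

The measured compounds so far:
- compound 1, `Oc1ccc(-c2cc(-c3cccnc3)nc(-c3ccccc3Cl)c2)cc1`, with an entry in a functional assay on T47D cells (Homo sapiens) for cytotoxicity, read by CCK-8 assay and cell counting, with a stated time of 2 days (on this read-out lower numbers stand for stronger inhibition and higher numbers for weaker inhibition), of "not determined" (no result reported)
- compound 2, `Oc1ccc(-c2cc(-c3cccc(Cl)c3)nc(-c3ccccn3)c2)cc1`, giving 27900 nM in this assay
- compound 3, `Oc1cccc(-c2cc(-c3ccc(Cl)cc3)nc(-c3cccs3)c2)c1`, giving 10500 nM in this assay

Of the two compounds with a number, compound 3 carries the lower one, and its gap to compound 2 lies beyond the usual scatter of this assay, so compound 3 stands as the stronger of that pair. Compound 1 contributes no number to the comparison.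

For the measured compounds named here, the next compound, compound 4 `Oc1cccc(-c2cc(-c3ccc(Cl)cc3)nc(-c3ccco3)c2)c1`, keeps the shared core of compound 3 and alters only one group: furan-2-yl in place of thiophen-2-yl on an aromatic carbon. The change is small, a five-membered aromatic ring with one hetero atom exchanged for another of the same size. Going by the values given here, no measured pair in this set shows such a swap, so there is no direct precedent to lean on. The expectation is a step of modest size from compound 3 to compound 4, most likely a slightly higher number, but one that may well stay within the scatter. The step expected is a 1.3-fold higher number from compound 3 to compound 4 (0.12 log units; within the scatter).

The estimate for compound 4 in this assay is 14000 nM, with a range from 5000 nM to 40000 nM.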

Compound 4, half-maximal inhibitory concentration: 10500 nM
For compound 4 the middle estimate is 1.3-fold (0.12 log units) above the measured one; the measured number falls inside the stated range.
By their numbers in this assay, from the lowest: compounds 3 and 4 (each within the scatter of the next); then compound 2.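

In this assay, placing furan-2-yl instead of thiophen-2-yl on the aromatic carbon next to the ring nitrogen gives no change at the digits printed from compound 3 to compound 4 (within the scatter). For the compounds shown here, this is the first comparison in the set that isolates a single place. The earlier compounds shown here differ from one another in more than one place. This comparison shows that exchanging the sulfur of this five-membered aromatic ring for oxygen leaves the read-out unmoved in this pair. Nothing available here explains why the two compounds read alike, so the result stands as an observation without a known cause.

Both groups compared at this position are five-membered aromatic rings of the same size with one hetero atom, so the result says nothing about how a different kind of group, such as an amine, a carboxylic acid or a longer alkyl chain, would read there. It also leaves open whether the same exchange would give the same outcome with groups other than the 3-hydroxyphenyl and 4-chlorophenyl groups on the shared core.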